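This account rests on a few compounds, and the source may have more. Where it says the series, first, only, none or still open, it means among the compounds named here.

Of the compounds shown here, three have so far been measured in a functional assay on HeLa cells (Homo sapiens) for antiproliferative activity, read by MTT assay, with a stated time of 72 h; on this read-out lower numbers stand for stronger inhibition and higher numbers for weaker inhibition. Compound 1 `Oc1ccc2ccccc2c1/C=N/NC(=S)Nc1ccccc1` gives 2000 nM. Compound 2 `COc1cccc(/C=N/NC(=S)Nc2ccccc2)c1O` gives 1700 nM, and compound 3 `CCN(CC)c1ccc(/C=N/NC(N)=S)c(O)c1` gives 2000 nM. Compound 2 has the lowest of the three numbers, but its gaps to compound 1 and to compound 3 both lie within the scatter, so nothing separates the three on this read-out. Compound 4 `Oc1ccccc1/C=N/NC(=S)Nc1ccccc1` has not yet been tested in this assay. It differs from compound 2 in a single place: hydrogen in place of methoxy on an aromatic carbon. Within the data shown here, no measured pair shows this particular change, so the account can lean only on how closely the three numbers in hand sit together despite their structural differences. The step this estimate means, a 1.5-fold higher number from compound 2 to compound 4 (0.17 log units; within the scatter), is expected to be small, a slight weakening at most and nothing beyond the scatter. Compound 4 is accordingly expected to give 2500 nM, within a range from 1200 nM to 5500 nM.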

Compound 4, half-maximal inhibitory concentration: 1500 nM
Compound 4: middle estimate off by 1.7-fold (0.22 log units), on the high side; the measured number falls inside the stated range.
By their numbers in this assay, from the lowest: compounds 4, 2, 1 and 3 (each within the scatter of the next).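

Hydrogen in place of methoxy on an aromatic carbon, ortho to a hydroxy group, gives a 1.1-fold lower number from compound 2 to compound 4 (0.05 log units; within the scatter) in this assay. Among these compounds, this pair is the first to isolate a single change, and it shows that the methoxy can leave this position with no shift beyond the scatter. Among the compounds shown here, the close agreement among the earlier compounds could only hint at this, because they differ in more than one place. No available evidence accounts for the result.

From the compounds shown here alone, whether this position would tolerate other groups, such as an ethoxy, an amine or a carboxylic acid, remains open. Also open, going by these compounds, is the role of the hydroxy group that compound 2 and compound 4 share, which could be probed by putting a methoxy or an amine in its place.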